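A few compounds are considered here, and "the series" means these few. Any claim that something is new, unique, unknown or untested is made for them only; others in the source may bear on it.

Working notes on the series in an assay for inhibition of histone-lysine N-methyltransferase, H3 lysine-79 specific (Homo sapiens), read by luminescence, with a stated time of 1 h; a higher number here means a weaker inhibitor, a lower number a stronger inhibitor.

The series shares one core carrying an amide-type nitrogen whose substituent varies. Compound 1 `Cc1ccc(NC(=O)c2ncn(CC(=O)NCCn3ccc4c(N)ncnc43)n2)cc1C` carries 3,4-dimethylphenyl there, and in this assay compound 1 gives 10900 nM. Compound 2 `CC(C)(C)c1ccc(NC(=O)c2ncn(CC(=O)NCCn3ccc4c(N)ncnc43)n2)cc1` carries 4-(tert-butyl)phenyl, and in this assay compound 2 gives 1000 nM. Going by the values given here, the single measured step, an 11-fold lower number from compound 1 to compound 2 (1.04 log units; beyond the scatter), is the only guide to how this position responds. Compound 2 thus stands with the lowest number of the two measured, its nearest neighbour being compound 1 with a higher number.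

Compound 3 `Nc1ncnc2c1ccn2CCNC(=O)Cn1cnc(C(=O)NC2CCCCC2)n1` is not yet measured. Its change from compound 2 is cyclohexyl in place of 4-(tert-butyl)phenyl on an amide-type nitrogen. Among the compounds with values here, the one measured step at this position changed one aromatic substituent for another; none changes an aromatic ring for a non-aromatic one, so no measured step bears directly on this change. The measured step does show that this position moves the number by a large amount.

Given that the only step at this position is an 11-fold lower number from compound 1 to compound 2 (1.04 log units; beyond the scatter), and that compound 3 loses the substituent that accompanied the lowest number, the step of a 4.0-fold higher number from compound 2 to compound 3 (0.60 log units; beyond the scatter) is expected to move the number upward, beyond the scatter. Compound 3 is accordingly estimated at 4000 nM, with a range of 1200 nM to 15000 nM.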

Compound 3, half-maximal inhibitory concentration: > 100000 nM
Compound 3 ended at the assay's limit; the forecaster's own chance of this, stated with the estimate: 10%; middle value at least 25-fold (1.39 log units) away from the limit.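

In this assay compound 3 gives > 100000 nM, which is a limit of the assay and not a number: the limit of > 100000 nM in this assay, at which 1 of the 3 values shown sits.

Cyclohexyl on the amide-type nitrogen gives an at least 100-fold higher number from compound 2 to compound 3 (2.00 log units; beyond the scatter), and measured against the weaker aromatic compound it gives an at least 9.1-fold higher number from compound 1 to compound 3 (0.96 log units; beyond the scatter). Going by these compounds alone, the earlier compounds showed only that this position responds to a change from one aromatic substituent to another, whereas these steps show that the two compounds with a six-membered aromatic ring of carbon only both read below the limit, and the one compound with a non-aromatic ring does not.

The single change from 4-(tert-butyl)phenyl to cyclohexyl removes the aromatic ring and the tert-butyl group together, so the compounds shown leave open which of the two goes with the loss; plain phenyl and 4-(tert-butyl)cyclohexyl on the same nitrogen would separate them. Also open, going by these compounds, is how an aromatic ring carrying an amine or a carboxylic acid in place of tert-butyl would read at this position.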